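A few compounds are considered here, and "the series" means these few. Any claim that something is new, unique, unknown or untested is made for them only; others in the source may bear on it.

Compounds 1, 2 and 3 share one core and differ only in the group attached to its six-membered aromatic ring with one nitrogen. Compound 1 `COc1ccnc(N2CCC(NC(=S)Nc3cccnc3)CC2)c1` carries a methoxy group there, while compound 2 `COc1ccc(Oc2ccnc(N3CCC(NC(=S)Nc4cccnc4)CC3)c2)cc1` carries a 4-methoxyphenoxy group. Within the data shown here, in an assay on membranes from brain for binding affinity to Lysophosphatidylserine lipase ABHD12 (Mus musculus), read by fluorescence, with a stated time of 20 min (on this read-out lower numbers stand for stronger inhibition and higher numbers for weaker inhibition), compound 2 gives 2900 nM, and this is the only number among the values shown. In this assay compound 1 gives > 5000 nM, which is a limit of the assay and not a measured number. Among the measured compounds shown here, the single measured step, an at least 1.7-fold lower number from compound 1 to compound 2 (0.23 log units; that floor lies within the scatter), therefore describes a move from a limit to a number, and its floor lies within the scatter.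

Compound 3 `FC(F)(F)c1ccnc(N2CCC(NC(=S)Nc3cccnc3)CC2)c1` differs from compound 2 by trifluoromethyl in place of 4-methoxyphenoxy on an aromatic carbon. This change bears a resemblance to the measured step run backwards, since it again swaps a large group for a small one at the same aromatic carbon. The number is therefore expected to rise, with a fair chance that only a limit is reported again. For compound 3 the estimate is 5000 nM, with a range from 2000 nM to 12000 nM, which means an expected step of a 1.7-fold higher number from compound 2 to compound 3 (0.24 log units; within the scatter).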

Compound 3, half-maximal inhibitory concentration: 640 nM
Beside the measured number, compound 3's estimate is 7.8-fold (0.89 log units) above it; the whole stated range lies above it.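

In this assay, a small group at this aromatic carbon, opposite the ring nitrogen, can outdo a large one: trifluoromethyl in place of 4-methoxyphenoxy gives a 4.5-fold lower number from compound 2 to compound 3 (0.66 log units; beyond the scatter), so the extra aromatic ring of compound 2 is not needed for a measurable number. Compound 1, which carries methoxy, stands at > 5000 nM, a limit of the assay and not a number. Two small groups at the same carbon therefore part ways, so size alone does not order these three groups, with trifluoromethyl in place of methoxy giving an at least 7.8-fold lower number from compound 1 to compound 3 (0.89 log units; beyond the scatter), and that step is only a floor because compound 1 sits at a limit: the limit of > 5000 nM in this assay, at which 1 of the 3 values shown sits.

The three compounds leave open whether trifluoromethyl is special here or whether other groups at this carbon, such as a chlorine atom, a nitrile, an ethyl chain or a dimethylamino group, would serve as well or better. They also leave open whether this step would hold once another part of the shared core is altered, as all three compounds keep the rest of it the same.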